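Carbonyl aryl group change from compound 3 to compound 4

The compounds below may be only part of what the source reports. "The series", "measured", "known", "first", "only" and "open" are said of these compounds alone.

compound 1 `COc1ccc(/C=C/c2cc(OC)cc(OC)c2/C=C/C(=O)c2cccc(Cl)c2)cc1`: 9.5 ug/mL
compound 2 `COc1ccc(/C=C/c2cc(OC)cc(OC)c2/C=C/C(=O)c2ccc(C)cc2C)cc1`: 0.9 ug/mL
compound 3 `COc1ccc(/C=C/c2cc(OC)cc(OC)c2/C=C/C(=O)c2ccc(C)c(C)c2)cc1`: 0.2 ug/mL

In a functional assay on HepG2 cells (Homo sapiens) for antiproliferative activity, read by MTT assay, with a stated time of 48 h (a lower number here means a stronger inhibitor, a higher number a weaker inhibitor), compound 3 gives the lowest of the three numbers, and its gaps to both other compounds lie beyond the scatter.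

The next change is 4-phenylphenyl in place of 3,4-dimethylphenyl on a carbonyl carbon, which gives compound 4 `COc1ccc(/C=C/c2cc(OC)cc(OC)c2/C=C/C(=O)c2ccc(-c3ccccc3)cc2)cc1`, with 4-phenylphenyl in place of 3,4-dimethylphenyl on a carbonyl carbon.

All three measured steps sit at this same place. an 11-fold lower number from compound 1 to compound 2 (1.02 log units; beyond the scatter) and a 48-fold lower number from compound 1 to compound 3 (1.68 log units; beyond the scatter) are both large, while a 4.5-fold lower number from compound 2 to compound 3 (0.65 log units; beyond the scatter) is modest. The number therefore moves widely with this group across these compounds, but none of them carries 4-phenylphenyl, so no direct read exists. With compound 3 at the low end, a higher number is expected, of about the size of the modest step of a 4.5-fold lower number from compound 2 to compound 3 (0.65 log units; beyond the scatter). The expected change is a 5.0-fold higher number from compound 3 to compound 4 (0.70 log units; beyond the scatter). In this assay the estimate for compound 4 is 1 ug/mL, with an expected range of 0.25 ug/mL to 5 ug/mL.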

Compound 4, half-maximal inhibitory concentration: 10.5 ug/mL
Compound 4: middle estimate off by 11-fold (1.02 log units), on the low side; measured number outside the range, above it.
By their numbers in this assay, from the lowest: compound 3; then compound 2; then compounds 1 and 4 (each within the scatter of the next).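

In this assay, the low numbers seen with the dimethylphenyl groups do not carry over to 4-phenylphenyl on the carbonyl carbon: the result is a 53-fold higher number from compound 3 to compound 4 (1.72 log units; beyond the scatter) and a 12-fold higher number from compound 2 to compound 4 (1.07 log units; beyond the scatter) as well. Against the 3-chlorophenyl compound the picture differs, with a 1.1-fold higher number from compound 1 to compound 4 (0.04 log units; within the scatter) and the two groups not separated, so among these four compounds only compound 2 and compound 3 reach the low numbers. Nothing available here explains why the second aromatic ring carries this cost.

Open, from the compounds shown here alone, is whether the low numbers need both methyl groups or whether a single methyl group on the phenyl ring would hold them. Also open, going by these compounds, is whether an amine or a carboxylic acid on the added phenyl ring would bring compound 4 back toward compound 3.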